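Swapping Bromo for Methoxy on the Aromatic Carbon

This account rests on a few compounds, and the source may have more. Where it says the series, first, only, none or still open, it means among the compounds named here.

Compound 3 `COC(=O)[C@@]1(C)CC[C@@H]2C3=C1CC[C@@H](C)[C@]3(C)Cc1c2[nH]c2ccc(Br)cc12` gives 17000 nM in a functional assay on A549 cells (Homo sapiens) for inhibition, read by sulforhodamine B assay, with a stated time of 48 h (on this read-out higher numbers stand for weaker inhibition of growth and lower numbers for stronger inhibition of growth), the highest of the three numbers shown. Its nearest neighbour is compound 2 `COC(=O)[C@@]1(C)CC[C@@H]2C3=C1CC[C@@H](C)[C@]3(C)Cc1c2[nH]c2ccc(C)cc12` with 16000 nM, and the parent compound 1 `COC(=O)[C@@]1(C)CC[C@@H]2C3=C1CC[C@@H](C)[C@]3(C)Cc1c2[nH]c2ccccc12` gives 4600 nM. The two substituted analogues sit close together, as a 1.1-fold higher number from compound 2 to compound 3 (0.03 log units; within the scatter) shows, while both steps from the parent, a 3.5-fold higher number from compound 1 to compound 2 (0.54 log units; beyond the scatter) and a 3.7-fold higher number from compound 1 to compound 3 (0.57 log units; beyond the scatter), were modest and alike in size. Compound 4 `COC(=O)[C@@]1(C)CC[C@@H]2C3=C1CC[C@@H](C)[C@]3(C)Cc1c2[nH]c2ccc(OC)cc12` carries a (methoxy in place of bromo on an aromatic carbon). Both measured substituents gave the same outcome, so a third substituent at this carbon is expected to leave this assay essentially unchanged: a 1.1-fold lower number from compound 3 to compound 4 (0.05 log units; within the scatter). Compound 4 is therefore estimated at 15000 nM, within a range of 6000 nM to 40000 nM.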

Compound 4, concentration for 50% growth inhibition: 7700 nM
Beside the measured number, compound 4's estimate is 1.9-fold (0.29 log units) above it; the measured number falls inside the stated range.
By their numbers in this assay, from the lowest: compounds 1 and 4 (each within the scatter of the next); then compounds 2 and 3 (each within the scatter of the next).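

At this carbon the outcome depends on the substituent: in this assay methoxy in place of bromo gave a 2.2-fold lower number from compound 3 to compound 4 (0.34 log units; beyond the scatter) and methoxy in place of methyl gave a 2.1-fold lower number from compound 2 to compound 4 (0.32 log units; beyond the scatter) so the match between methyl and bromo does not extend to methoxy. Methoxy in place of hydrogen gave a 1.7-fold higher number from compound 1 to compound 4 (0.22 log units; within the scatter) and so, of the three substituents, only methoxy is not set apart from the unsubstituted compound. No measurement at hand accounts for this difference.

Going by these compounds, whether an amine, a carboxylic acid or a longer chain at this carbon would fall with methoxy or with methyl and bromo remains open. So does whether methoxy would behave alike on other carbons of the shared core.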